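This account rests on a few compounds, and the source may have more. Where it says the series, first, only, none or still open, it means among the compounds named here.

Compound 1 `C/C=C/C(=O)Nc1c(C(O)(C(F)(F)F)C(F)(F)F)ccc2ccccc12` gives 96% in a functional assay (Sus scrofa) with sulfonylurea receptors; K-ATP channels (Homo sapiens) as the target; a higher number here means a larger maximal response, a lower number a smaller maximal response. Compound 2 `O=C(Nc1c(C(O)(C(F)(F)F)C(F)(F)F)ccc2ccccc12)C1CC1` gives 100%. Compound 3 `O=C(Nc1c(C(O)(C(F)(F)F)C(F)(F)F)ccc2ccccc12)c1cccc([N+](=O)[O-])c1` gives 99%.

Compound 3 stands second highest of the three numbers; its nearest neighbour is compound 2, with a number 1 percentage points lower from compound 2 to compound 3 (within the scatter), and the furthest is compound 1, with a number 3 percentage points higher from compound 1 to compound 3 (within the scatter). Compound 4 `O=C(Nc1c(C(O)(C(F)(F)F)C(F)(F)F)ccc2ccccc12)c1ccc(Cl)cc1` differs from compound 3 only at the carbonyl carbon: 4-chlorophenyl in place of 3-nitrophenyl on a carbonyl carbon. Every measured step also exchanges the group on that carbonyl carbon, and each lies within the scatter: a number 4 percentage points higher from compound 1 to compound 2 (within the scatter), a number 3 percentage points higher from compound 1 to compound 3 (within the scatter) and a number 1 percentage points lower from compound 2 to compound 3 (within the scatter). He therefore expects no step beyond the scatter in this assay, so compound 4 is estimated at 98%, within 86% to 106%. The estimated step is a number 1 percentage points lower from compound 3 to compound 4 (within the scatter).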

Compound 4, largest response reached (reported as efficacy), in percent of the reference or control that the assay uses: 99%
Compound 4: the middle estimate sits 1 percentage points below what was measured; low and high end bracket the measured number.
By their numbers in this assay, from the lowest: compounds 1, 3, 4 and 2 (each within the scatter of the next).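

Exchanging 3-nitrophenyl for 4-chlorophenyl on the carbonyl carbon removes the hydrogen-bond acceptors of the leaving group and brings in chlorine, yet this assay shows (no change at the digits printed from compound 3 to compound 4 (within the scatter)). The same holds against the two groups without an aromatic ring (a number 1 percentage points lower from compound 2 to compound 4 (within the scatter)) and (a number 3 percentage points higher from compound 1 to compound 4 (within the scatter)), so a chlorine-bearing ring fits the pattern of the other three compounds at this position. No evidence is available that would explain this result.

Going by these compounds, whether an amine, a carboxylic acid or a longer chain on this carbonyl carbon would keep the response remains open. No group shown so far moves the number beyond the scatter, so what this position demands is still unknown.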